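This account rests on a few compounds, and the source may have more. Where it says the series, first, only, none or still open, it means among the compounds named here.

Of the compounds shown here, three with a shared core have been measured in a functional assay on 1321-N1 cells for agonist activity at Free fatty acid receptor 1 (Homo sapiens), read by calcium flux, with a stated time of 0.4 s; on this read-out higher numbers stand for an effect only at larger amounts of compound and lower numbers for an effect already at smaller amounts. Compound 1 `O=C(O)CCc1ccc(C#CC2CC2)cc1` carries a cyclopropyl on a triple-bonded carbon and gives 5010 nM. Compound 3 `C=C(C)C#Cc1ccc(CCC(=O)O)cc1` instead carries a 1-methylethenyl there and gives 417 nM. Compound 2 `C/C(C#Cc1ccc(CCC(=O)O)c(F)c1)=C/CO` adds a fluorine to the core and a 3-hydroxy-1-methylprop-1-en-1-yl on the triple-bonded carbon, and gives 427 nM.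

Among these three numbers compound 2 stands second highest; its value and that of compound 3 are within the usual scatter of each other, while compound 1 sits well above both. Among the compounds with values here, the only single-place step measured is a 12-fold lower number from compound 1 to compound 3 (1.08 log units; beyond the scatter), a change of the group on the triple-bonded carbon.

Compound 4 `C/C=C(\C)C#Cc1ccc(CCC(=O)O)c(F)c1` arises from compound 2 by a change at the same place: 1-methylprop-1-en-1-yl in place of 3-hydroxy-1-methylprop-1-en-1-yl on a triple-bonded carbon. Put plainly, the 1-methylprop-1-en-1-yl keeps the carbon chain but drops the hydrogen-bond donor and acceptor that the 3-hydroxy-1-methylprop-1-en-1-yl held. Within the data shown here, no measured step tests this exact change; the step from compound 1 to compound 3 swaps a ring for an open chain and says little about a hydroxy loss. Compound 3, which also lacks that donor, gives a value close to compound 2, so no step beyond the scatter is expected for a 1.2-fold higher number from compound 2 to compound 4 (0.07 log units; within the scatter). Compound 4 is therefore estimated at 500 nM, within 150 nM to 1700 nM.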

Compound 4, half-maximal effective concentration: 37.2 nM
Compound 4: middle estimate off by 13-fold (1.13 log units), on the high side, and the stated range ends above it.
By their numbers in this assay, from the lowest: compound 4; then compounds 3 and 2 (each within the scatter of the next); then compound 1.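

The change at this place in this assay gives an 11-fold lower number from compound 2 to compound 4 (1.06 log units; beyond the scatter) and so is beyond the scatter. The earlier step swapped a ring for an open chain, whereas this one shows that the same triple-bonded carbon also responds strongly to a change within an open chain, where the 1-methylprop-1-en-1-yl and the 3-hydroxy-1-methylprop-1-en-1-yl share their carbon count and their double bond and differ in the hydroxy group. In this pair the group with 0 hydrogen-bond donors and 0 hydrogen-bond acceptors has the lower number, so a hydroxy group on this chain is not required for an effect at smaller amounts of compound, and no other measurement here explains why the step is so large.

Still open, going by these compounds, is whether the same step would appear on the shared core without the fluorine. It is also unclear how this carbon would respond if the hydroxy group gave way to a methoxy group, an amine or a carboxylic acid, or if the 1-methylprop-1-en-1-yl were extended to a longer chain.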